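The source may report more compounds than this note shows. Statements on the series, on what has been measured and on what is new or still open speak of the compounds shown alone.

Within the data shown here, in an ADME assay on microsomes from liver (Rattus norvegicus) for metabolic stability, read by LC-MS, using NADPH, with a stated time of 10 min, tested at 0.1 uM (on this read-out lower numbers stand for slow clearance and higher numbers for fast clearance), three compounds have numbers so far. Compound 1 (`COc1ccc(F)cc1N1C(=O)CSC1c1cccc(C(=O)NCCCCc2ccccc2)c1`) gives 2300 mL.min-1.g-1 and compound 2 (`Cc1cccc(N2C(=O)CSC2c2cccc(C(=O)NCCCCc3ccccc3)c2)c1`) gives 3140 mL.min-1.g-1 in the same test. Compound 3 (`O=C(NCCCCn1cccn1)c1cccc(C2SCC(=O)N2c2ccccn2)c1`) gives 506 mL.min-1.g-1 as the lowest of the three numbers. Compound 4 (`O=C(NCCCCc1ccccc1)c1cccc(C2SCC(=O)N2c2ccccn2)c1`) has phenyl in place of 1H-pyrazol-1-yl on a saturated chain carbon, four bonds along the chain from an amide-type nitrogen. Among the measured compounds shown here, no measured step covers this exact swap. For the measured compounds named here, the only step, a 1.4-fold higher number from compound 1 to compound 2 (0.14 log units; within the scatter), lies within the scatter and concerns the group on an amide-type nitrogen in a ring. Compound 1 and compound 2 share the phenyl end of compound 4 and stand well above compound 3, but they also differ from it on that ring nitrogen. The gap therefore cannot be assigned to the chain end alone, and only part of it is expected to carry over. The expected step is a 2.8-fold higher number from compound 3 to compound 4 (0.44 log units; beyond the scatter), toward faster clearance. For compound 4 the estimate is 1400 mL.min-1.g-1, with an expected range from 600 mL.min-1.g-1 to 3000 mL.min-1.g-1 as its upper end.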

Compound 4, intrinsic clearance in microsomes: 1480 mL.min-1.g-1
Compound 4: the middle estimate sits 1.1-fold (0.02 log units) below what was measured, and the stated range covers the measured number.
By their numbers in this assay, from the lowest: compound 3; then compounds 4, 1 and 2 (each within the scatter of the next, the first and the last beyond it).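

In this assay, the chain end now has a step of its own, with the rest of the molecule unchanged: phenyl in place of 1H-pyrazol-1-yl gives a modest rise in clearance (a 2.9-fold higher number from compound 3 to compound 4 (0.47 log units; beyond the scatter)). With the phenyl chain end kept, the group on the ring nitrogen can matter too: pyridin-2-yl in place of 3-methylphenyl gives a modest fall beyond the scatter (a 2.1-fold lower number from compound 2 to compound 4 (0.33 log units; beyond the scatter)), whereas pyridin-2-yl in place of 5-fluoro-2-methoxyphenyl stays within the scatter (a 1.6-fold lower number from compound 1 to compound 4 (0.19 log units; within the scatter)). Nothing available explains the size of any of these steps.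

The compounds shown leave open whether 1H-pyrazol-1-yl would give a similar step with 3-methylphenyl or 5-fluoro-2-methoxyphenyl on the ring nitrogen. They also leave open how an amine or a carboxylic acid at the chain end, or a longer chain, would read.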